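Compound 3 to compound 4: one substituted phenyl for another

The compounds below may be only part of what the source reports. "The series", "measured", "known", "first", "only" and "open" are said of these compounds alone.

In a functional assay on A549 cells (Homo sapiens) for antiproliferative activity, read by MTT assay, with a stated time of 72 h (a lower number here means a stronger inhibitor, a higher number a weaker inhibitor), compound 1 `CN1CCN(C(=S)SCc2ccc3nc(N)nc(N)c3c2)CC1` gives 9200 nM, compound 2 `Cc1ccc(N2CCN(C(=S)SCc3ccc4nc(N)nc(N)c4c3)CC2)cc1` gives 2190 nM and compound 3 `Cc1ccccc1N1CCN(C(=S)SCc2ccc3nc(N)nc(N)c3c2)CC1` gives 3920 nM. Compound 3 thus stands within the scatter of compound 2 and below compound 1.

Compound 4 `Nc1nc(N)c2cc(CSC(=S)N3CCN(c4ccc(F)cc4F)CC3)ccc2n1` carries 2,4-difluorophenyl in place of 2-methylphenyl on an amine nitrogen in a ring.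

The steps from methyl to a methylphenyl group were modest, a 4.2-fold lower number from compound 1 to compound 2 (0.62 log units; beyond the scatter) and a 2.3-fold lower number from compound 1 to compound 3 (0.37 log units; beyond the scatter). Exchange between the two methylphenyl groups gave only a 1.8-fold higher number from compound 2 to compound 3 (0.25 log units; within the scatter), within the scatter. Among the measured compounds shown here, the closest precedent is that last step, so the expected change in this assay stays within the scatter, with no firm direction: an estimated 1.3-fold lower number from compound 3 to compound 4 (0.12 log units; within the scatter). For compound 4 the estimated value is 3000 nM, with an expected range of 1300 nM to 7000 nM.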

Compound 4, half-maximal inhibitory concentration: 5120 nM
Estimate against measurement, compound 4: 1.7-fold (0.23 log units) below; the range from low to high includes it.
By their numbers in this assay, from the lowest: compounds 2, 3, 4 and 1 (each within the scatter of the next, the first and the last beyond it).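

In this assay the exchange of 2-methylphenyl for 2,4-difluorophenyl gives a 1.3-fold higher number from compound 3 to compound 4 (0.12 log units; within the scatter) and so separates the two groups by no more than the scatter. Against 4-methylphenyl the same group gives a 2.3-fold higher number from compound 2 to compound 4 (0.37 log units; beyond the scatter) but against methyl it gives a 1.8-fold lower number from compound 1 to compound 4 (0.25 log units; within the scatter) and this last step stays within the scatter. The separation from methyl seen beyond the scatter for compounds 2 and 3 is thus not seen for compound 4. No supporting data explain these differences.

Open, as far as these compounds go, is whether a single fluorine on the phenyl ring would match the methylphenyl compounds. Also open, from the compounds shown here alone, is how an amine or carboxylic acid on the phenyl ring would read.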